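Benzyl ester in place of the terminal amide

The source may hold more compounds than are shown below. What is called first, only, known or untested is meant among the compounds shown, and "the series" means these compounds.

The series shares one core, shown in compound 1 `Cc1cn([C@@H]2O[C@H](CO[Si](C)(C)C(C)(C)C)[C@@]3(OS(=O)(=O)C=C3NCCC(N)=O)[C@H]2O[Si](C)(C)C(C)(C)C)c(=O)n(C)c1=O`, and is followed in a functional assay on HEL cells (Homo sapiens); on this read-out lower numbers stand for higher toxicity in this test and higher numbers for lower toxicity in this test. Compound 1 gives 14800 nM, the second highest of the three numbers measured. Compound 2 `Cc1cn([C@@H]2O[C@H](CO[Si](C)(C)C(C)(C)C)[C@@]3(OS(=O)(=O)C=C3NC(N)=O)[C@H]2O[Si](C)(C)C(C)(C)C)c(=O)n(C)c1=O` gives 11000 nM, and the step of a 1.3-fold lower number from compound 1 to compound 2 (0.13 log units; within the scatter) shows no difference beyond the scatter. Compound 3 `Cc1cn([C@@H]2O[C@H](CO[Si](C)(C)C(C)(C)C)[C@@]3(OS(=O)(=O)C=C3NCCC(=O)O)[C@H]2O[Si](C)(C)C(C)(C)C)c(=O)n(C)c1=O` gives 34000 nM, and the step of a 2.3-fold higher number from compound 1 to compound 3 (0.36 log units; beyond the scatter) is a modest one; the step of a 3.1-fold higher number from compound 2 to compound 3 (0.49 log units; beyond the scatter) points the same way.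

Compound 4 `Cc1cn([C@@H]2O[C@H](CO[Si](C)(C)C(C)(C)C)[C@@]3(OS(=O)(=O)C=C3NCC(=O)OCc3ccccc3)[C@H]2O[Si](C)(C)C(C)(C)C)c(=O)n(C)c1=O` differs from compound 1 in one place: benzyloxycarbonyl in place of carbamoylmethyl on a saturated chain carbon bound to an amine nitrogen. Among the compounds with values here, two measured steps bear on this. The step of a 1.3-fold lower number from compound 1 to compound 2 (0.13 log units; within the scatter) shows that changing the length of the chain on the amine nitrogen while keeping the amide moves this assay little. The step of a 2.3-fold higher number from compound 1 to compound 3 (0.36 log units; beyond the scatter) shows that exchanging the amino of the amide for hydroxy raises the number modestly. Compound 4 removes the amide altogether and brings in an ester with a benzyl group, a change larger than either measured one, so no direction is secured by the data. The step from compound 1 to compound 4 is therefore expected to be small, a 1.2-fold lower number from compound 1 to compound 4 (0.09 log units; within the scatter), with a wide range. Compound 4 is estimated at 12000 nM, between 4000 nM and 40000 nM.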

Compound 4, half-maximal cytotoxic concentration: > 200000 nM
Compound 4: a limit, no number; the forecaster's own chance of this, stated with the estimate: 10%; middle value at least 16-fold (1.22 log units) away from the limit.
By their numbers in this assay, from the lowest: compounds 2 and 1 (each within the scatter of the next); then compound 3. At a limit, above all of these: compound 4.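

In this assay compound 4 stands at a limit of the assay and not at a number: the limit of > 200000 nM in this assay, at which 1 of the 4 values shown sits. Set against that limit, the chain on the amine nitrogen proves far from indifferent to what it carries, with an at least 13-fold higher number from compound 1 to compound 4 (1.13 log units; beyond the scatter) and an at least 18-fold higher number from compound 2 to compound 4 (1.25 log units; beyond the scatter), while from the earlier number that stood highest there is an at least 5.8-fold higher number from compound 3 to compound 4 (0.76 log units; beyond the scatter). Within the data shown here, the earlier changes among amide and acid on this chain stayed within the scatter or gave modest steps, so (benzyloxycarbonyl)methyl is the first group here to bring a large move towards lower toxicity in this test, and the true size of that move remains bounded only from one side.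

Compound 4 changes the ester, the benzyl group and the chain together, so the compounds shown do not tell which of these carries the step. As far as these compounds go, whether a methyl ester on the same chain, a benzyl amide, or a longer chain ending in the benzyl ester would also reach this limit stays open, as does where compound 4 itself lies beyond it.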